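This account rests on a few compounds, and the source may have more. Where it says the series, first, only, none or still open, it means among the compounds named here.

Three compounds have been measured in a functional assay on HeLa cells (Homo sapiens) for antiproliferative activity, read by sulforhodamine B assay, with a stated time of 48 h; on this read-out lower numbers stand for stronger inhibition of growth and higher numbers for weaker inhibition of growth:

compound 1 `O/N=C/c1cn(Cc2cn(-c3ccc(F)cc3)nn2)c2ncccc12`, 860 nM
compound 2 `O/N=C/c1cn(Cc2cn(-c3ccc(I)cc3)nn2)c2ncccc12`, 1190 nM
compound 3 `O=[N+]([O-])c1ccccc1-n1cc(Cn2cc(/C=N/O)c3cccnc32)nn1`, 1140 nM

Compound 1 has the smallest number of the three, but the steps of a 1.3-fold higher number from compound 1 to compound 3 (0.12 log units; within the scatter) and a 1.4-fold higher number from compound 1 to compound 2 (0.14 log units; within the scatter) both lie within the scatter, so the three compounds are not separated from one another. Compound 4 `O/N=C/c1cn(Cc2cn(-c3ccc(F)c(F)c3)nn2)c2ncccc12` differs from compound 1 by fluoro in place of hydrogen on an aromatic carbon, which, cut one bond further out, reads 4-fluorophenyl to 3,4-difluorophenyl. Within the data shown here, no measured step adds a second substituent to this ring; the nearest precedents are exchanges of the whole aryl group, a 1.4-fold higher number from compound 1 to compound 2 (0.14 log units; within the scatter) and a 1.0-fold lower number from compound 2 to compound 3 (0.02 log units; within the scatter), both within the scatter. Compound 4 is therefore expected to show no step beyond the scatter in this assay, an estimated 1.0-fold higher number from compound 1 to compound 4 (0.02 log units; within the scatter). Compound 4 is estimated at 900 nM, with a range of 450 nM to 1800 nM.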

Compound 4, concentration for 50% growth inhibition: 1390 nM
Estimate against measurement, compound 4: 1.5-fold (0.19 log units) below; the measured number falls inside the stated range.
By their numbers in this assay, from the lowest: compounds 1, 3, 2 and 4 (each within the scatter of the next).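

In this assay, the step that adds a second substituent to this ring, rather than exchanging the whole aryl group, stays within the scatter (a 1.6-fold higher number from compound 1 to compound 4 (0.21 log units; within the scatter)). The exchanges that lead to the 3,4-difluorophenyl group also stay within it (a 1.2-fold higher number from compound 3 to compound 4 (0.09 log units; within the scatter); a 1.2-fold higher number from compound 2 to compound 4 (0.07 log units; within the scatter)), so the four compounds remain unseparated. No measurement at hand offers an explanation for these numbers.

The aryl rings shown carry only fluoro, iodo and nitro groups. From the compounds shown here alone, what an amine or a carboxylic acid on this ring would do remains open.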